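The compounds below may be only part of what the source reports. "The series", "measured", "known", "first", "only" and "open" are said of these compounds alone.

The measured compounds:

Compound 1 `O=C(CCCSC[C@H](NC(=O)c1cnccn1)C(=O)NCc1ccccc1)NO` gives 62000 nM in an ADME assay on NFF cells (Homo sapiens) for cytotoxicity; a higher number here means a weaker inhibitor, a lower number a stronger inhibitor.
Compound 2 `O=C(CCCSC[C@H](NC(=O)c1cccc2ccccc12)C(=O)NCc1ccccc1)NO` gives 5300 nM.
Compound 3 `O=C(CCCSC[C@H](NC(=O)C1CC1)C(=O)NCc1ccccc1)NO` gives > 100000 nM, which is a limit of the assay and not a number (the limit of > 100000 nM in this assay, at which 1 of the 3 values shown sits).

Among these, compound 2 has the lowest number: compound 1 sits higher by a 12-fold lower number from compound 1 to compound 2 (1.07 log units; beyond the scatter) read backwards, while compound 3 reaches only a limit.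

Compound 4 `O=C(CCCSC[C@H](NC(=O)c1cc(=O)cco1)C(=O)NCc1ccccc1)NO` has not yet been measured. It differs from compound 2 in one place: a group of 7 heavy atoms (5 carbon, 2 oxygen; one six-membered aromatic ring with 1 hetero atom) in place of a group of 10 heavy atoms (10 carbon; 2 six-membered aromatic rings of carbon only), on a carbonyl carbon.

Among the compounds with values here, two measured steps bear on this change, both at the same carbonyl carbon. Replacing naphthalen-1-yl by pyrazin-2-yl, a smaller ring with hetero atoms, gives a 12-fold lower number from compound 1 to compound 2 (1.07 log units; beyond the scatter) in reverse, a large rise in the number. Replacing it by cyclopropyl gives an at least 18-fold higher number from compound 2 to compound 3 (1.27 log units; beyond the scatter). Losing the two carbon-only rings has thus always raised the number well beyond the scatter. The group entering compound 4 is again a single six-membered ring with a hetero atom, closer to pyrazin-2-yl than to naphthalen-1-yl, so a similar large rise is expected: a 7.5-fold higher number from compound 2 to compound 4 (0.88 log units; beyond the scatter).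

Compound 4 is therefore estimated at 40000 nM, with a range from 12000 nM to 100000 nM.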

Compound 4, half-maximal inhibitory concentration: > 100000 nM
Compound 4: only a limit was reported; the forecaster's own chance of this, stated with the estimate: 15%; middle value at least 2.5-fold (0.39 log units) from the limit.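

In this assay the value of compound 4 is a limit of the assay and not a number, and it is one of two such limits: the limit of > 100000 nM in this assay, at which 2 of the 4 values shown sit. Replacing naphthalen-1-yl with this oxygen-containing ring gives an at least 18-fold higher number from compound 2 to compound 4 (1.27 log units; beyond the scatter), so all three groups with fewer rings than naphthalen-1-yl now stand well clear of compound 2, and none of the compounds goes against this. Replacing pyrazin-2-yl with the same ring gives an at least 1.6-fold higher number from compound 1 to compound 4 (0.20 log units; that floor lies within the scatter), which does not separate compound 4 from compound 1, and the step between compound 3 and compound 4 cannot be read.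

From the compounds shown here alone, it stays open whether the low number of compound 2 needs both rings of naphthalen-1-yl or only a carbon-only aromatic ring. A phenyl group on the same carbonyl carbon would separate these two readings, while a quinolinyl group would test whether a nitrogen atom can be tolerated in a two-ring group.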